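Compound 4: a carbamoyl group on the shared core

The source may hold more compounds than are shown below. What is called first, only, known or untested is meant among the compounds shown, and "the series" means these compounds.

Measured in an ADME assay on the whole organism (Rattus norvegicus), at a dose of 0.5 mg/kg by the intravenous route; on this read-out lower numbers stand for lower exposure and higher numbers for higher exposure at the dose given:
Compound 1 `Cc1nn(C(C)c2ccc(Cl)cc2Cl)c2nc(N3CCC(N4CCCCC4)C(C)C3)cnc12`: 217 ng.h/mL
Compound 2 `CC1CN(c2cnc3c(C#N)nn(C(C)c4ccc(Cl)cc4Cl)c3n2)CCC1N1CCCCC1`: 82 ng.h/mL
Compound 3 `CC1CN(c2cnc3cnn(C(C)c4ccc(Cl)cc4Cl)c3n2)CCC1N1CCCCC1`: 68 ng.h/mL

Compound 3, at 68 ng.h/mL, cannot be told apart from compound 2, as the data show a 1.2-fold lower number from compound 2 to compound 3 (0.08 log units; within the scatter). Only compound 1 stands clear of it, with a 3.2-fold lower number from compound 1 to compound 3 (0.50 log units; beyond the scatter). Compound 4 `CC1CN(c2cnc3c(C(N)=O)nn(C(C)c4ccc(Cl)cc4Cl)c3n2)CCC1N1CCCCC1` is related to compound 3 by one change: carbamoyl in place of hydrogen on an aromatic carbon. Among the measured compounds shown here, compounds 1 and 2 carry methyl and cyano on that same aromatic carbon, so these two steps are the only guides, one modest and one within the scatter. In this assay a small rise is expected, with the estimate being a 1.5-fold higher number from compound 3 to compound 4 (0.17 log units; within the scatter). The value estimated for compound 4 is 100 ng.h/mL, with an expected range of 45 ng.h/mL to 230 ng.h/mL.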

Compound 4, area under the concentration-time curve: 82 ng.h/mL
The estimate for compound 4 lay 1.2-fold (0.09 log units) above the measured number; low and high end bracket the measured number.
By their numbers in this assay, from the lowest: compounds 3, 2 and 4 (each within the scatter of the next); then compound 1.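

With a 1.2-fold higher number from compound 3 to compound 4 (0.08 log units; within the scatter) and no change at the digits printed from compound 2 to compound 4 (within the scatter) in this assay carbamoyl on this aromatic carbon cannot be told apart from hydrogen or cyano. With a 2.6-fold lower number from compound 1 to compound 4 (0.42 log units; beyond the scatter) it also falls clear of methyl, so among these four compounds methyl alone stands apart from the other three groups at this position. Nothing on hand explains these numbers. From the compounds shown here alone, whether an amine, a carboxylic acid or a longer chain on this carbon would stand with methyl or with the other three remains open.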